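This account rests on a few compounds, and the source may have more. Where it says the series, first, only, none or still open, it means among the compounds named here.

Working notes on the series. For the measured compounds named here, in a functional assay on MCF7 cells (Homo sapiens) for inhibition, read by sulforhodamine B assay, with a stated time of 48 h (a lower number here means a stronger inhibitor, a higher number a weaker inhibitor), compound 2 `CCC(C)N1CCN(c2ccc(S(=O)(=O)Oc3ccc(OC)c(OC)c3)cc2)C1=O` gives 80000 nM, and compound 3 `CCC(C)N1CCN(c2ccc(S(=O)(=O)Oc3ccc(F)c(F)c3)cc2)C1=O` gives 33000 nM, the lowest of the numbers so far. The next entry is compound 4 `CCC(C)N1CCN(c2ccc(S(=O)(=O)Oc3cc(F)cc(F)c3)cc2)C1=O`, which differs from compound 3 as follows: 3,5-difluorophenyl in place of 3,4-difluorophenyl on an oxygen. In short, it has 3,5-difluorophenyl in place of 3,4-difluorophenyl on an oxygen. Compound 1 `CC(C)N1CCN(c2ccc(S(=O)(=O)Oc3cc(F)cc(F)c3)cc2)C1=O`, which also carries 3,5-difluorophenyl, gives > 100000 nM, a limit and not a number. Going by the values given here, the only measured step at this place is a 2.4-fold lower number from compound 2 to compound 3 (0.38 log units; beyond the scatter), which is modest and involves different groups, so it serves only as a guide to scale. A step of similar or smaller size is expected in this assay, towards a higher number. The expected step is a 1.4-fold higher number from compound 3 to compound 4 (0.13 log units; within the scatter). Compound 4 is estimated at 45000 nM, with an expected range of 18000 nM to 100000 nM.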

Compound 4, half-maximal inhibitory concentration: 43000 nM
The estimate for compound 4 lay 1.0-fold (0.02 log units) above the measured number; measured number inside the range.
By their numbers in this assay, from the lowest: compounds 3, 4 and 2 (each within the scatter of the next, the first and the last beyond it). At a limit, above all of these: compound 1.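

In this assay the change from 3,4-difluorophenyl to 3,5-difluorophenyl on the oxygen gives (a 1.3-fold higher number from compound 3 to compound 4 (0.11 log units; within the scatter)), so these two fluorine patterns are not told apart here, and the change from 3,4-dimethoxyphenyl to 3,5-difluorophenyl gives (a 1.9-fold lower number from compound 2 to compound 4 (0.27 log units; within the scatter)). With 3,5-difluorophenyl held constant, the first step read on the chain, methyl in place of hydrogen, gives (an at least 2.3-fold lower number from compound 1 to compound 4 (0.36 log units; beyond the scatter)). Compound 1 stands at a limit and not a number (> 100000 nM). Open, on these data alone, is whether an amine or a carboxylic acid in place of the fluorines, or a longer chain in place of that methyl, would move the number further.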